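Trifluoromethyl on the fused ring and metabolic stability

A few compounds are considered here, and "the series" means these few. Any claim that something is new, unique, unknown or untested is made for them only; others in the source may bear on it.

Compound 1 `Fc1cc(Cl)ccc1-c1ccc(Cn2nnc3ccccc32)cn1` is the parent of the first pair. In an ADME assay on microsomes from liver (Mus musculus, strain NMRI) for metabolic stability, tested at 2.5 uM (on this read-out lower numbers stand for slow clearance and higher numbers for fast clearance), compound 1 gives 3.4 mL/min/g. Compound 2 `Fc1cc(Cl)ccc1-c1ccc(Cn2nnc3c(C(F)(F)F)cccc32)cn1` carries one change against it: trifluoromethyl in place of hydrogen on an aromatic carbon. In this assay compound 2 gives 0.1 mL/min/g, a step of a 34-fold lower number from compound 1 to compound 2 (1.53 log units; beyond the scatter).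

Compound 3 `Brc1cccc2c1nnn2CC1CC1` rests on a different core; how the two cores differ is not broken down here. In this assay compound 3 gives 7.7 mL/min/g, the highest number of the three measured, with every step to the others beyond the scatter.

Compound 4 `FC(F)(F)c1cc(Br)c2nnn(CC3CC3)c2c1` is to be measured and differs from compound 3 by trifluoromethyl in place of hydrogen on an aromatic carbon. This is the same kind of change as that from compound 1 to compound 2, but the surroundings are not the same: here the group sits meta to a bromo group, meta to a fused ring and para to a fused ring, whereas in compound 2 it sits ortho to a fused ring and meta to a fused ring.

For the measured compounds named here, because the step of a 34-fold lower number from compound 1 to compound 2 (1.53 log units; beyond the scatter) was large, a lowering is expected for compound 4 in this assay too, estimated at a 9.6-fold lower number from compound 3 to compound 4 (0.98 log units; beyond the scatter), set somewhat smaller as the place differs and only one such pair is measured. The expected value of compound 4 is 0.8 mL/min/g, estimated between 0.2 mL/min/g and 3 mL/min/g.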

Compound 4, intrinsic clearance in a liver preparation (reported as CLH), per the amount of preparation that the assay uses: 7.7 mL/min/g
For compound 4 the middle estimate is 9.6-fold (0.98 log units) below the measured one; the measured number lies above the stated range.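

On the core of compound 3, trifluoromethyl in place of hydrogen on an aromatic carbon gives no change at the digits printed from compound 3 to compound 4 (within the scatter), so the large lowering seen on the core of compound 1 does not carry over to this pair. The two steps for the same change differ by more than the scatter allows: the same change on two cores in this assay, a 34-fold lower number (1.53 log units; beyond the scatter) from compound 1 to compound 2 and no change at the digits printed (within the scatter) from compound 3 to compound 4, 34-fold (1.53 log units) apart, beyond the scatter of two such steps This shows that in this assay the step cannot be transferred as a fixed amount from one core to the other, but it does not show what sets the gap, as the two pairs differ in core, in the surrounding groups and in the place of the trifluoromethyl group, and one pair per core supports no rule for other cores.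

Still open, on these data alone, is whether the core of compound 1 would keep its lowering with the group in the place it holds in compound 4, and whether the core of compound 3 would show a lowering with the group in the place it holds in compound 2. Also open, as far as these compounds go, is how a nitrile, a methoxy group or an amine on the same carbon would read in this assay.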